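Hydroxy for methoxy on a chloro-aryl pyrazole urea

The source may hold more compounds than are shown below. What is called first, only, known or untested is meant among the compounds shown, and "the series" means these compounds.

Compound 1 `O=C(Nc1cccc(-n2cc(-c3ccncc3)c(-c3ccc(Cl)c(O)c3)n2)c1)Nc1cccc(C(F)(F)F)c1`: in a functional assay on MDA-MB-468 cells (Homo sapiens) for inhibition, read by sulforhodamine B assay, with a stated time of 48 h (on this read-out lower numbers stand for higher toxicity in this test and higher numbers for lower toxicity in this test), compound 1 gives only the limit > 32500 nM.
Compound 2 `COc1cc(-c2nn(-c3cccc(NC(=O)c4cccc(C(F)(F)F)c4)c3)cc2-c2ccncc2)ccc1Cl`: in this assay compound 2 gives only the limit > 50000 nM.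
Compound 3 `COc1cc(-c2nn(-c3cccc(NC(=O)Nc4ccc(Cl)c(Cl)c4)c3)cc2-c2ccncc2)ccc1Cl`: in this assay compound 3 gives only the limit > 50000 nM.

Compound 3 therefore stands at a limit, not a number, as do both other compounds, one at the limit of > 32500 nM in this assay, at which 1 of the 3 values shown sits, and two at the limit of > 50000 nM in this assay, at which 2 of the 3 values shown sit. For the measured compounds named here, the one measured step, a step that the two limits leave unreadable from compound 2 to compound 3, cannot be read either. Compound 4 `O=C(Nc1cccc(-n2cc(-c3ccncc3)c(-c3ccc(Cl)c(O)c3)n2)c1)Nc1ccc(Cl)c(Cl)c1` differs from compound 3 by hydrogen in place of methyl on an oxygen on an aromatic ring. Going by the values given here, no measured step covers this change, so no direction beyond the scatter can be expected; compound 1 carries the same hydroxy group and gives a limit. Compound 4 is therefore expected to give a limit as well, estimated at 60000 nM (range 20000 nM to 200000 nM), an expected step that the limit leaves unreadable from compound 3 to compound 4.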

Compound 4, concentration lethal to 50% of the cells: > 32500 nM
Compound 4 ended at the assay's limit (the forecaster's own chance of this, stated with the estimate: 85%); the middle value is on the limit's open side.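

Compound 4 gives only a limit, as do compound 1 and compound 3, so neither new step can be read. The compounds shown leave open whether hydroxy for methoxy changes the result in this assay at all.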